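The compounds below may be only part of what the source reports. "The series", "measured", "known", "first", "only" and "open" are said of these compounds alone.

Working notes on the series at the point before compound 4 is measured.

Compound 3 `COc1ccc(-c2cccc(C(=O)N(C)C)c2)cc1S(=O)(=O)Nc1cccc(NCCNC(=O)c2ccccc2Cl)c1` gives 50% in a functional assay on CHO-K1 cells for agonist activity at Orexin/Hypocretin receptor type 1 (Homo sapiens), read by calcium flux; on this read-out higher numbers stand for larger maximal responses and lower numbers for smaller maximal responses. Two numbers are known in this assay. Going by the values given here, compound 1 `COc1cccc(C(=O)NCCNc2cccc(NS(=O)(=O)c3cc(-c4cccc(C(=O)N(C)C)c4)ccc3OC)c2)c1` gives 49%, and the single step of a number 1 percentage points higher from compound 1 to compound 3 (within the scatter) lies within the scatter, so compound 3 and compound 1 are not distinguishable on this read-out. Compound 2 `COc1ccc(-c2cccc(C(=O)N(C)C)c2)cc1S(=O)(=O)Nc1cccc(NCCNC(=O)c2ccccc2C)c1` has no result in this assay: "not determined" (no result reported).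

The next compound is compound 4 `COc1ccc(-c2cccc(C(=O)N(C)C)c2)cc1S(=O)(=O)Nc1cccc(NCCNC(=O)c2cccc(Cl)c2)c1`. Its difference from compound 3 is 3-chlorophenyl in place of 2-chlorophenyl on a carbonyl carbon.

Among the compounds with values here, the only measured step that bears on this position is the one from compound 1 to compound 3, where the whole aryl group on the carbonyl carbon was exchanged and the response hardly moved: a number 1 percentage points higher from compound 1 to compound 3 (within the scatter). Shifting the chlorine from 2-chlorophenyl to 3-chlorophenyl is a smaller change at the same place, and no step in this series argues for a move beyond the scatter. The step of no change at the digits printed from compound 3 to compound 4 (within the scatter) is therefore expected to stay within the scatter. Compound 4 is expected to give 50%, with a range from 38% to 62%.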

Compound 4, largest response reached (Emax), in percent of the reference or control that the assay uses: 73%
Compound 4: the middle estimate sits 23 percentage points below what was measured; the whole stated range lies below it.
By their numbers in this assay, from the lowest: compounds 1 and 3 (each within the scatter of the next); then compound 4.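

In this assay, going by these compounds alone, where the chlorine sits on the aryl group on the carbonyl carbon matters: with the same atoms joined differently, 3-chlorophenyl in place of 2-chlorophenyl gives a number 23 percentage points higher from compound 3 to compound 4 (beyond the scatter) and is the first step beyond the scatter. The same place also separates 3-chlorophenyl from 3-methoxyphenyl, with chloro in place of methoxy on an aromatic carbon giving a number 24 percentage points higher from compound 1 to compound 4 (beyond the scatter) as a result, whereas the earlier step of a number 1 percentage points higher from compound 1 to compound 3 (within the scatter) showed no such separation. Nothing available here accounts for these differences.

Still open, from the compounds shown here alone, is whether the higher response is particular to chlorine or also holds for other groups on the phenyl ring, such as an amine or a carboxylic acid. Also open, going by these compounds, is how a longer chain between the two amide-bearing parts of the molecule would read out with 3-chlorophenyl in place.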